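This account rests on a few compounds, and the source may have more. Where it says the series, first, only, none or still open, it means among the compounds named here.

In an ADME assay on HEK293 cells (Homo sapiens) for cytotoxicity, read by resazurin assay, with a stated time of 48 h (a higher number here means that more compound is tolerated, a lower number that less compound is tolerated), the series comprises compound 1 (`O=S(=O)(Nc1ccc2oc(-c3ccccc3)nc2c1)c1cccc(F)c1`), compound 2 (`O=S(=O)(Nc1ccc(-c2nc3ccccc3o2)cc1)c1cccc(Cl)c1`), compound 3 (`O=S(=O)(Nc1ccc(-c2nc3ccccc3o2)cc1)c1cccc(C(F)(F)F)c1`) and the unmeasured compound 4 (`COc1ccccc1S(=O)(=O)Nc1ccc(-c2nc3ccccc3o2)cc1`). Compound 2 gives > 100000 nM, which is a limit and not a number. Compound 3 gives > 100000 nM, also a limit. Differing from compound 2 in more than one place, compound 1 gives 68000 nM, a readable number. The data therefore centre on (the limit of > 100000 nM in this assay, at which 2 of the 3 values shown sit).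

The change under review is 2-methoxyphenyl in place of 3-chlorophenyl on a sulfonyl sulfur, with 2-methoxyphenyl in place of 3-chlorophenyl on a sulfonyl sulfur. Among the compounds with values here, the only measured step is a step that the two limits leave unreadable from compound 2 to compound 3, with trifluoromethyl in place of chloro on an aromatic carbon, and it does not cover this change. Since a step that the two limits leave unreadable from compound 2 to compound 3 offers no size to carry over, no step beyond the scatter is expected in this assay. The expected step of an at least 1.1-fold lower number from compound 2 to compound 4 (0.04 log units; that floor lies within the scatter) has no favoured direction. Compound 4 is estimated at 90000 nM, with an expected range of 40000 nM to 200000 nM.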

Compound 4, half-maximal cytotoxic concentration: > 100000 nM
Compound 4: no number, only a limit; the forecaster's own chance of this, stated with the estimate: 60%; at least 1.1-fold (0.04 log units) between middle value and limit.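

Compound 2 and compound 4 both give only a limit in this assay, so no step can be read between them. The compounds shown leave open whether 2-methoxyphenyl in place of 3-chlorophenyl on a sulfonyl sulfur changes the tolerated concentration at all, and in which direction.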